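A few compounds are considered here, and "the series" means these few. Any claim that something is new, unique, unknown or untested is made for them only; others in the source may bear on it.

Compound 1, with the structure `CCc1nnc([S+]([O-])Cc2ncc(C)c(OC)c2C)o1`, was tested in a functional assay on HUVEC cells (Homo sapiens) for inhibition, read by ELISA (on this read-out lower numbers stand for stronger inhibition and higher numbers for weaker inhibition), where compound 1 gives 10000 nM. Going by the values given here, only one other compound has a number on the same read-out: compound 2, built as `[O-][S+](Cc1ccccc1)c1nnc(-c2cccnc2)o1`, for which this assay gives 6000 nM. On paper compound 1 carries the larger of the two numbers, but the gap to compound 2 falls inside the scatter of repeated measurements, so the two cannot be told apart; both sit at the weak end of what this assay can resolve.

Compound 3, drawn as `COc1c(C)cnc(C[S+]([O-])c2nnc(C)o2)c1C`, has not been measured. It differs from compound 1 in a single place, (hydrogen in place of methyl on a saturated chain carbon bound to an aromatic carbon), so that the chain on the shared core shrinks by one carbon. Among the compounds with values here, no pair of measured compounds shows what such a swap does here, so the expectation rests on the smallness of the change alone: a step that is estimated to stay within the scatter, no change at the digits printed from compound 1 to compound 3 (within the scatter), in no clear direction. Compound 3 is therefore expected to give about 10000 nM, most likely between 4000 nM and 30000 nM.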

Compound 3, half-maximal inhibitory concentration: 8000 nM
Compound 3: the middle estimate sits 1.3-fold (0.10 log units) above what was measured; low and high end bracket the measured number.
By their numbers in this assay, from the lowest: compounds 2, 3 and 1 (each within the scatter of the next).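

Shortening the ethyl group to methyl on the shared core gives the first single-place comparison in this assay (a step of a 1.3-fold lower number from compound 1 to compound 3 (0.10 log units; within the scatter)). At this place, on a saturated chain carbon bound to an aromatic carbon, the read-out therefore does not separate ethyl from methyl, and removing this one carbon gives no difference that can be told from the spread of repeated measurements. No independent measurement is available to explain this result.

Going by these compounds alone, what stays open is whether a bigger change at this place, such as a longer chain like butyl, a phenyl ring or an amine, would shift the number beyond the scatter, as ethyl to methyl is the only swap that can be read here. On these data alone, compound 2 differs from compound 1 and compound 3 in more than one place, so it adds nothing about this position, and the effect of any single change elsewhere on the shared core remains unknown.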